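The source may report more compounds than this note shows. Statements on the series, on what has been measured and on what is new or still open speak of the compounds shown alone.

Measured so far in a functional assay for agonist activity at Free fatty acid receptor 1 (Homo sapiens); on this read-out lower numbers stand for an effect already at smaller amounts and higher numbers for an effect only at larger amounts of compound:
compound 1 `O=C(O)CCc1ccc(NCc2ccccc2)cc1` — 7940 nM
compound 2 `O=C(O)CCc1ccc(NCc2ccc(O)cc2)cc1` — < 31700 nM
compound 3 `N#Cc1ccc(CNc2ccc(CCC(=O)O)cc2)cc1` — < 31700 nM

For the measured compounds named here, compound 1 is the only member of the set with a read number; in this assay compound 1 gives 7940 nM. For compound 2 this assay reports only a limit, < 31700 nM. For compound 3 likewise only a limit is reported, < 31700 nM, so compound 3 cannot be placed against the others by number. The steps a step that the limit leaves unreadable from compound 1 to compound 2 and a step that the limit leaves unreadable from compound 1 to compound 3 are therefore of unknown size, as is a step that the two limits leave unreadable from compound 2 to compound 3; the reason is the limit of < 31700 nM in this assay, at which 2 of the 3 values shown sit.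

Compound 4 `COc1ccc(CNc2ccc(CCC(=O)O)cc2)cc1` is not yet measured. It differs from compound 3 by methoxy in place of cyano on an aromatic carbon. Going by the values given here, no measured step carries a methoxy, and the cyano step is unreadable, so the direction of the change is open. Among the compounds with values here, the only fixed point is compound 1 with 7940 nM. Compound 4 is expected to land near that value, estimated at 5000 nM with a range of 1000 nM to 25000 nM; the implied step that the limit leaves unreadable from compound 3 to compound 4 is an expectation only.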

Compound 4, half-maximal effective concentration: 1260 nM
The estimate for compound 4 lay 4.0-fold (0.60 log units) above the measured number, and the stated range covers the measured number.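

At this position in this assay, the series now has its first readable step for a substituent: a 6.3-fold lower number from compound 1 to compound 4 (0.80 log units; beyond the scatter), with methoxy in place of hydrogen. For the compounds shown here, compound 4 thus shows that a group on this aromatic carbon, para to a large group, can go with a lower number than the unsubstituted compound 1, which the earlier compounds could not show. The steps from compound 4 to compound 2 and compound 3 still cannot be read, so methoxy cannot be ranked against hydroxy or cyano because of the assay limit: the limit of < 31700 nM in this assay, at which 2 of the 4 values shown sit.

As far as these compounds go, one readable step gives no trend, so it remains open whether the change is specific to methoxy. Also open, from the compounds shown here alone, is how a longer ether such as ethoxy, or an amine, would read at this same place.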